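The source may hold more compounds than are shown below. What is called first, only, known or untested is meant among the compounds shown, and "the series" means these compounds.

Compound 1 `CN1CCN(c2cccc3[nH]c(C(=O)c4ccccc4)nc23)CC1` and compound 2 `c1ccc2c(Cc3nc4cc(N5CCNCC5)ccc4[nH]3)cccc2c1` share a core and were both tested in an assay on HEK293 cells for displacement of a labelled ligand from 5-hydroxytryptamine receptor 6 (Homo sapiens), read by scintillation counting; a lower number here means a stronger inhibitor, a higher number a weaker inhibitor. In this assay compound 1 gives > 1000 nM, which is a limit of the assay rather than a number. In this assay compound 2 gives > 1000 nM, again a limit and not a number. Compound 2 therefore stands where all the data stand, at the limit of > 1000 nM in this assay, at which 2 of the 2 values shown sit. Compound 3 `CN1CCN(c2ccc3[nH]c(Cc4cccc5ccccc45)nc3c2)CC1` differs from compound 2 by methyl in place of hydrogen on an amine nitrogen in a ring, read one bond further out as piperazin-1-yl to 4-methylpiperazin-1-yl. For the measured compounds named here, no measured pair shows this change, so no measured step can be cited for it. The step is estimated as a step that the limit leaves unreadable from compound 2 to compound 3, nothing beyond the scatter in either direction. Compound 3 is accordingly expected to give about 2000 nM in this assay, within a range from 500 nM to 8000 nM.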

Compound 3, inhibition constant: > 1000 nM
Compound 3 was reported as a limit (the forecaster's own chance of this, stated with the estimate: 70%); the middle value does not contradict the limit.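

For the compounds shown here, compound 2 and compound 3 are both reported only as limits, so no step between them can be read. The compounds shown leave open how strong an inhibitor any of them is in this assay, because all of them sit at one limit: the limit of > 1000 nM in this assay, at which 3 of the 3 values shown sit.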